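The compounds below may be only part of what the source reports. "The series", "measured", "known", "first", "only" and "open" are said of these compounds alone.

Measured compounds and their values:

Compound 1, `CC(C)(C)c1ccc(C(=O)N2CCC3(CC2)C(=O)N(CC(=O)NCCCN)CN3c2ccccc2)cc1`, gives 4200 nM in an assay on HEK293 cells for displacement of a labelled ligand from NPC1-like intracellular cholesterol transporter 1 (Homo sapiens); on this read-out lower numbers stand for stronger inhibition and higher numbers for weaker inhibition.
Compound 2, `CC(C)(C)c1ccc(C(=O)N2CCC3(CC2)C(=O)N(CC(=O)NCNS(C)(=O)=O)CN3c2ccccc2)cc1`, gives 3200 nM in this assay.
Compound 3, `NC(=O)C1CCCN(C(=O)CN2CN(c3ccccc3)C3(CCN(C(=O)c4ccc(C5CCCCC5)cc4)CC3)C2=O)C1`, gives 3100 nM in this assay.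

In this assay compound 2 holds the second highest of the three numbers; its nearest neighbour is compound 3, and all three values sit within the scatter of one another, so no order among them can be drawn.

The step under consideration goes from compound 2 to compound 4, `CC(C)(C)c1ccc(C(=O)N2CCC3(CC2)C(=O)N(CC(=O)NCCCCN)CN3c2ccccc2)cc1`. The structural change is 3-aminopropyl in place of methanesulfonamido on a saturated chain carbon bound to an amide-type nitrogen, so that the side chain on the core of compound 2 becomes a 4-aminobutyl group in place of a (methanesulfonamido)methyl group.

For the measured compounds named here, only one measured step bears on this change, and it runs the other way: a 1.3-fold lower number from compound 1 to compound 2 (0.12 log units; within the scatter). Compound 4 therefore returns to a chain of the kind found in compound 1, lengthened by one carbon, and the values of compound 1 and compound 2 lie within the scatter of each other. No step beyond the scatter is expected in this assay in either direction.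

For compound 4 the expected step is a 1.2-fold higher number from compound 2 to compound 4 (0.07 log units; within the scatter), and the estimated value is 3800 nM, with a range of 1900 nM to 7600 nM.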

Compound 4, half-maximal inhibitory concentration: 14500 nM
For compound 4 the middle estimate is 3.8-fold (0.58 log units) below the measured one; measured number outside the range, above it.
By their numbers in this assay, from the lowest: compounds 3, 2 and 1 (each within the scatter of the next); then compound 4.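

In this assay this side chain first shows a step beyond the scatter: replacing (methanesulfonamido)methyl with 4-aminobutyl gives a 4.5-fold higher number from compound 2 to compound 4 (0.66 log units; beyond the scatter) and so weaker inhibition, whereas the step between compound 1 and compound 2 gave no readable change. Chain length alone also counts, since the change from 3-aminopropyl to 4-aminobutyl gives a 3.5-fold higher number from compound 1 to compound 4 (0.54 log units; beyond the scatter) even though both chains end in an amine, so a terminal amine does not by itself set the number in the compounds shown. No measurement on hand explains either step.

From the compounds shown here alone, whether the number keeps climbing with a longer chain such as 5-aminopentyl, or whether the 4-aminobutyl result depends on the terminal amine, which a hydroxyl or a carboxylic acid at the same chain end would test, remains open. A shorter amine chain such as 2-aminoethyl would show whether the value of compound 1 in this assay (4200 nM) belongs to a flat stretch of chain lengths or to a steady trend.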